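The source may hold more compounds than are shown below. What is called first, only, known or untested is meant among the compounds shown, and "the series" means these compounds.

Values in an assay on isolated protein with metabotropic glutamate receptor 1 (Homo sapiens) as the target (a lower number here means that less compound is needed, a higher number that more compound is needed for the effect), for the measured members of the series:

- compound 1, `CN(C)Cc1cn(CC(=O)Nc2sc3c(c2C(N)=O)CCCC3)nc1C(C)(C)C`: 316 nM
- compound 2, `NCc1cn(CC(=O)Nc2sc3c(c2C(N)=O)CCCC3)nc1C(F)(F)F`: 794 nM
- compound 3, `CC(C)NCc1cn(CC(=O)Nc2sc3c(c2C(N)=O)CCCC3)nc1C(C)(C)C`: 1580 nM

Compound 2 holds the second highest of the three numbers. Its nearest neighbour is compound 3, whose value lies within the scatter of that of compound 2, so the two are not separated. Compound 1 stands furthest off, with a lower number than compound 2 that lies beyond the scatter.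

The next compound in line is compound 4, `CN(C)Cc1cn(CC(=O)Nc2sc3c(c2C(N)=O)CCCC3)nc1C(F)(F)F`. It differs from compound 2 in one place: dimethylamino in place of amino on a saturated chain carbon bound to an aromatic carbon

For the measured compounds named here, only one measured step bears on this position: a 5.0-fold higher number from compound 1 to compound 3 (0.70 log units; beyond the scatter). There the dimethylamino member gave the lower number. Going by the values given here, no measured pair covers amino against dimethylamino directly, and the substituent partner on the core differs between compound 1 and compound 2, so the transfer is indirect. Still, compound 1, the other dimethylamino member, gives 316 nM, a lower number than compound 2. A modest decrease in this assay is therefore expected for compound 4, probably at the edge of the scatter. The estimate for compound 4 is 400 nM, with a range of 150 nM to 1000 nM. This estimate means a step of a 2.0-fold lower number from compound 2 to compound 4 (0.30 log units; within the scatter).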

Compound 4, half-maximal effective concentration: 501 nM
Compound 4: the middle estimate sits 1.3-fold (0.10 log units) below what was measured; low and high end bracket the measured number.
By their numbers in this assay, from the lowest: compounds 1, 4, 2 and 3 (each within the scatter of the next, the first and the last beyond it).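

In this assay, for the compounds shown here, the exchange of amino for dimethylamino on a saturated chain carbon bound to an aromatic carbon, read directly for the first time with trifluoromethyl held constant, stays within the scatter (a 1.6-fold lower number from compound 2 to compound 4 (0.20 log units; within the scatter)), so this change does not separate the two compounds, whereas the earlier isopropylamino change, made with tert-butyl held constant, lies beyond it (a 5.0-fold higher number from compound 1 to compound 3 (0.70 log units; beyond the scatter)). Going by these compounds alone, the result also gives the first direct reading of the other variable group: with dimethylamino held constant, trifluoromethyl in place of tert-butyl on an aromatic carbon likewise stays within the scatter (a 1.6-fold higher number from compound 1 to compound 4 (0.20 log units; within the scatter)), so neither single change to compound 4 produces a separable shift in this small set. No measured information is available to explain these results.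

Still open, going by these compounds, is whether isopropylamino gives a separable step when trifluoromethyl rather than tert-butyl is the partner, and how amino reads with tert-butyl as the partner. The compounds shown also leave open how a cyclic amine such as pyrrolidine or morpholine, or a longer chain such as diethylamino, would read in place of dimethylamino.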